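The source may hold more compounds than are shown below. What is called first, only, known or untested is meant among the compounds shown, and "the series" means these compounds.

Measured so far in a functional assay on A549 cells (Homo sapiens) for cytotoxicity, read by MTT assay, with a stated time of 24 h; a higher number here means a weaker inhibitor, a lower number a stronger inhibitor:
Compound 1, `Cc1cc(-c2nc3ccccc3o2)ccc1NC(=O)CCl`, gives 33500 nM.
Compound 2, `Cc1cc(-c2nc3cc(Cl)ccc3o2)ccc1NC(=O)CCl`, gives 91500 nM.
Compound 3, `CN(C)CCCN1CCN(CC(=O)Nc2ccc(-c3nc4ccccc4o3)cc2)CC1`, gives 18300 nM.

Compound 1 and compound 2 differ in a single place, (chloro in place of hydrogen on an aromatic carbon), and the measured step is a 2.7-fold higher number from compound 1 to compound 2 (0.44 log units; beyond the scatter). Compound 3 carries a different core from compound 1; how the two cores differ is not broken down here. The values of compound 3 and compound 1 lie within the scatter of each other, so no order between them is read; compound 2 stands apart from both, beyond the scatter.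

Compound 4, `CN(C)CCCN1CCN(CC(=O)Nc2ccc(-c3nc4cc(Cl)ccc4o3)cc2)CC1`, has not been measured. It arises from compound 3 by chloro in place of hydrogen on an aromatic carbon, the same change as from compound 1 to compound 2, at a place described in the same words. Within the data shown here, because the single measured instance of this change is a 2.7-fold higher number from compound 1 to compound 2 (0.44 log units; beyond the scatter), the expected step in this assay is a 2.5-fold higher number from compound 3 to compound 4 (0.39 log units; beyond the scatter), a higher number, resting on that one precedent alone while the core difference remains unquantified. Compound 4 is therefore estimated at 45000 nM in this assay, with a range from 20000 nM to 110000 nM.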

Compound 4, half-maximal inhibitory concentration: 4320 nM
Estimate against measurement, compound 4: 10-fold (1.02 log units) above, outside the stated range (below it).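

In this assay chloro in place of hydrogen on an aromatic carbon, here 1,3-benzoxazol-2-yl to 5-chloro-1,3-benzoxazol-2-yl, gives a 4.2-fold lower number from compound 3 to compound 4 (0.63 log units; beyond the scatter) and so runs opposite to the step on the core of compound 1. The two instances of this change do not agree, in direction or in size: the same change on two cores in this assay, a 2.7-fold higher number (0.44 log units; beyond the scatter) from compound 1 to compound 2 and a 4.2-fold lower number (0.63 log units; beyond the scatter) from compound 3 to compound 4, 12-fold (1.06 log units) apart, beyond the scatter of two such steps. In this series the step measured on one core therefore does not transfer to the other, but the data do not show which part of the core difference decides the outcome, and one pair per core cannot say how general either step is.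

Still open, on these data alone, is whether another group at the same place, such as fluoro, methoxy or a nitrile, would follow chloro on each core or part from it in the same way. Also open, as far as these compounds go, is whether a shorter amine chain or a carboxylic acid in place of the dimethylamino end would keep the step seen on the core of compound 3.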